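Swapping a bridged bicyclic sulfonamide for a diethylamino sulfonamide

This account rests on a few compounds, and the source may have more. Where it says the series, first, only, none or still open, it means among the compounds named here.

Two compounds of this series carry a measured value. Compound 1 `O=C(NCc1ccncc1)Nc1ccc(S(=O)(=O)N2CC3CCC(C2)O3)cc1` gives 279 nM in an assay on isolated protein for activation of Nicotinamide phosphoribosyltransferase (Homo sapiens) (on this read-out higher numbers stand for an effect only at larger amounts of compound and lower numbers for an effect already at smaller amounts), the highest of the two numbers seen so far. Compound 2 `O=C(NCc1cnco1)Nc1ccc(S(=O)(=O)c2ccccc2)cc1` gives 77 nM in this assay, a lower number than compound 1 by more than the usual scatter. The two differ in more than one place, so no single step can be read from them.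

Compound 3 `CCN(CC)S(=O)(=O)c1ccc(NC(=O)NCc2ccncc2)cc1` has not yet been measured. It arises from compound 1 by one change on a sulfonyl sulfur: a group of 5 heavy atoms (4 carbon, 1 nitrogen; no ring) in place of a group of 8 heavy atoms (6 carbon, 1 nitrogen, 1 oxygen; one five-membered non-aromatic ring with 1 hetero atom, one six-membered non-aromatic ring with 2 hetero atoms), on a sulfonyl sulfur. Among the compounds with values here, no measured pair isolates this change. Since the urea and pyridinylmethyl parts of compound 1 are kept, the step of a 1.4-fold higher number from compound 1 to compound 3 (0.16 log units; within the scatter) is expected to be small, possibly within the scatter, with a slight lean toward a higher number. Compound 3 is therefore estimated at 400 nM in this assay, with a plausible range from 150 nM to 1200 nM.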

Compound 3, half-maximal effective concentration: 384 nM
For compound 3 the middle estimate is 1.0-fold (0.02 log units) above the measured one, and the stated range covers the measured number.
By their numbers in this assay, from the lowest: compound 2; then compounds 1 and 3 (each within the scatter of the next).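

On the sulfonyl sulfur of compound 1, diethylamino can take the place of the group of 8 heavy atoms: in this assay this exchange reads as a 1.4-fold higher number from compound 1 to compound 3 (0.14 log units; within the scatter). This is the first pair shown that differs in one place only, and on this read-out it does not separate the two groups, so for this pair neither the two rings nor the hydrogen-bond acceptor of the departing group proves necessary. No measurement at hand accounts for this result.

Still open, from the compounds shown here alone, is how a longer chain such as dipropylamino, or a smaller group such as dimethylamino, would read on the same sulfonyl sulfur. Equally open, going by these compounds, is whether a piperidine or morpholine ring there, or a carboxylic acid carried on the chain, would move the number beyond the scatter.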